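Dropping a Methoxy Group: Cytotoxicity Expectations

The source may hold more compounds than are shown below. What is called first, only, known or untested is meant among the compounds shown, and "the series" means these compounds.

For the measured compounds named here, compound 1 `COc1ccc(NC(=S)OCCNC(=O)C(C)(C)Oc2ccc(Cl)cc2)cc1` is one of two compounds measured so far. In an ADME assay on RAW264.7 cells (Mus musculus) for cytotoxicity, read by MTT assay, with a stated time of 48 h (a lower number here means a stronger inhibitor, a higher number a weaker inhibitor), compound 1 gives > 800000 nM, which is a limit of the assay rather than a number. Compound 2 `Cc1cnc(C(=O)Oc2ccc(C(N)=S)cc2)c[n+]1[O-]` likewise reaches only a limit in this assay, at > 800000 nM. Both results therefore sit at the same limit, as the limit of > 800000 nM in this assay, at which 2 of the 2 values shown sit, shows. Compound 3 `CC(C)(Oc1ccc(Cl)cc1)C(=O)NCCOC(=S)Nc1ccccc1` differs from compound 1 by hydrogen in place of methoxy on an aromatic carbon. Because compound 1 sits at the limit of > 800000 nM in this assay, at which 2 of the 2 values shown sit, no step beyond the usual scatter is expected in this assay. Compound 3 is estimated at 1000000 nM, within 300000 nM to 3000000 nM. The expected step that the limit leaves unreadable from compound 1 to compound 3 is thus essentially none.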

Compound 3, half-maximal inhibitory concentration: > 800000 nM
Compound 3: only a limit was reported (the forecaster's own chance of this, stated with the estimate: 85%); the middle value is on the limit's open side.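

Compound 1 and compound 3 both give only a limit of the assay, so no step can be read between them: the limit of > 800000 nM in this assay, at which 3 of the 3 values shown sit. Going by these compounds, whether hydrogen in place of methoxy changes the result in this assay at all remains open.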